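Aryl tail variation in a carbamate polyketide series

The source may hold more compounds than are shown below. What is called first, only, known or untested is meant among the compounds shown, and "the series" means these compounds.

Measured in a functional assay on MCF7 cells (Homo sapiens) for cytotoxicity; a higher number here means a weaker inhibitor, a lower number a stronger inhibitor: compound 1 `C=C/C=C\[C@H](C)[C@H](OC(N)=O)[C@@H](C)[C@H](O)[C@@H](C)C/C(C)=C\[C@H](C)[C@@H](O)[C@@H](C)/C=C\CCc1ccsc1` gives 4000 nM. Compound 2 `C=C/C=C\[C@H](C)[C@H](OC(N)=O)[C@@H](C)[C@H](O)[C@@H](C)C/C(C)=C\[C@H](C)[C@@H](O)[C@@H](C)/C=C\CCc1cccc(O)c1C` gives 1000 nM. Compound 3 `C=C/C=C\[C@H](C)[C@H](OC(N)=O)[C@@H](C)[C@H](O)[C@@H](C)C/C(C)=C\[C@H](C)[C@@H](O)[C@@H](C)/C=C\CCc1cc(O)cc(O)c1` gives only the limit > 1000 nM, not a number.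

Compound 3 therefore stands at a limit of this assay, with no readable number. Compound 4 `C=C/C=C\[C@H](C)[C@H](OC(N)=O)[C@@H](C)[C@H](O)[C@@H](C)C/C(C)=C\[C@H](C)[C@@H](O)[C@@H](C)/C=C\CCc1sccc1C` differs from compound 3 by 3-methylthiophen-2-yl in place of 3,5-dihydroxyphenyl on a saturated chain carbon, two bonds along the chain from a double-bonded chain carbon. Of the measured steps, a 4.0-fold lower number from compound 1 to compound 2 (0.60 log units; beyond the scatter) bears on the exchange of a thiophene for a hydroxylated phenyl; a step that the limit leaves unreadable from compound 1 to compound 3 and a number no lower from compound 2 to compound 3 (the limit leaves the size open) stay unreadable because of the limit of > 1000 nM in this assay, at which 1 of the 3 values shown sits. Compound 4 returns to a thiophene tail, so a number near compound 1 4000 nM is expected in this assay. The expected step is a step that the limit leaves unreadable from compound 3 to compound 4, its direction open. Compound 4 is estimated at 3000 nM, between 1000 nM and 10000 nM.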

Compound 4, half-maximal inhibitory concentration: 620 nM
The estimate for compound 4 lay 4.8-fold (0.68 log units) above the measured number; the whole stated range lies above it.
By their numbers in this assay, from the lowest: compounds 4 and 2 (each within the scatter of the next); then compound 1.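

In this assay, a thiophene tail on a saturated chain carbon, two bonds along the chain from a double-bonded chain carbon, need not stay at the level of thiophen-3-yl: 3-methylthiophen-2-yl gives a 6.5-fold lower number from compound 1 to compound 4 (0.81 log units; beyond the scatter). Against the hydroxylated phenyl tail there is a 1.6-fold lower number from compound 2 to compound 4 (0.21 log units; within the scatter), so a tail without hydroxyl reaches that level. Only a floor can be read for the 3,5-dihydroxyphenyl exchange, an at least 1.6-fold lower number from compound 3 to compound 4 (0.20 log units; that floor lies within the scatter), and it rests on a limit: the limit of > 1000 nM in this assay, at which 1 of the 4 values shown sits.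

The compounds shown do not separate the added methyl from the changed ring attachment. On these data alone, whether an unsubstituted thiophen-2-yl tail or a pyridine tail holds this level stays open.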